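The source may report more compounds than this note shows. Statements on the series, on what has been measured and on what is new or still open speak of the compounds shown alone.

In a functional assay on P388 cells (Mus musculus) for inhibition, read by MTT assay (on this read-out higher numbers stand for weaker inhibition and lower numbers for stronger inhibition), compound 2 `CC(=O)OC1C#CCCCCC#C/C1=C\c1ccccc1` gives 48000 nM, the highest number of the two measured compounds. Its nearest neighbour, compound 1 `COc1ccc(/C=C2\C#CCCCCC#CC2O)cc1`, gives 5800 nM, a gap beyond the usual scatter, though these two structures differ in more than one place. Compound 3 `COc1ccc(/C=C2\C#CCCCCC#CC2OC(C)=O)cc1` differs from compound 2 by methoxy in place of hydrogen on an aromatic carbon. Going by the values given here, no measured pair shows this change on its own, so in this assay only a modest move toward stronger inhibition is expected, estimated as a 2.4-fold lower number from compound 2 to compound 3 (0.38 log units; beyond the scatter). Compound 3 is accordingly expected to give about 20000 nM, within a range of 6000 nM to 60000 nM.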

Compound 3, half-maximal inhibitory concentration: 15000 nM
For compound 3 the middle estimate is 1.3-fold (0.12 log units) above the measured one; the range from low to high includes it.
By their numbers in this assay, from the lowest: compound 1; then compound 3; then compound 2.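

In this assay, going by these compounds alone, methoxy in place of hydrogen on an aromatic carbon, para to a large group, gives a 3.2-fold lower number from compound 2 to compound 3 (0.51 log units; beyond the scatter), the first direct reading of this change. Acetyl in place of hydrogen on an oxygen on a saturated carbon gives a 2.6-fold higher number from compound 1 to compound 3 (0.41 log units; beyond the scatter), so on this core the acetylated compound inhibits more weakly. No evidence at hand explains either step.

Each change is read on a single pair, so neither can be called general. From the compounds shown here alone, whether an amine on the aromatic ring, or a longer chain in place of acetyl, would move the number further remains open.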